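The source may report more compounds than this note shows. Statements on the series, on what has been measured and on what is new or still open speak of the compounds shown alone.

Measured in a physicochemical assay for lipophilicity, read by HPLC; on this read-out higher numbers stand for higher lipophilicity and lower numbers for lower lipophilicity:
compound 1 `CCCCn1cc(C(=O)NCc2ccccc2)c(=O)c2cc(F)c(N(C)C)cc21`: 2.4
compound 2 `NC(=O)C1CCN(c2cc3c(cc2F)c(=O)c(C(=O)NCc2ccccc2)cn3C2CC2)CC1`: 2.4
compound 3 `CCCCn1cc(C(=O)NCc2ccc(OC)cc2)c(=O)c2cc(F)c(N3CCC(C(N)=O)CC3)cc21`: 2.4

Compound 3 stands level with compound 1 and compound 2 in this assay, all three reading the same at the digits reported. Not yet measured is compound 4 `CCCCn1cc(C(=O)NCc2ccccc2)c(=O)c2cc(F)c(N3CCC(C(N)=O)CC3)cc21`, which carries hydrogen in place of methoxy on an aromatic carbon, para to a large group: hydrogen in place of methoxy on an aromatic carbon. In other words, 4-methoxybenzyl becomes benzyl. Among the compounds with values here, no measured pair differs in one place only, so the expectation rests on compound 3 at 2.4 and on the structural change alone. A small downward move or none is expected, and the estimated a number 0.10 log units lower from compound 3 to compound 4 (within the scatter) stays within the scatter. For compound 4 the estimated value in this assay is 2.3, with an expected range of 2 to 2.6.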

Compound 4, partition coefficient: 2.4
Estimate against measurement, compound 4: 0.10 log units below, within the range that was stated.
By their numbers in this assay, from the lowest: compounds 1, 2, 3 and 4 (each within the scatter of the next).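

In this assay, hydrogen in place of methoxy on the aromatic carbon gives no change at the digits printed from compound 3 to compound 4 (within the scatter), so benzyl and 4-methoxybenzyl read alike here. Butyl in place of cyclopropyl on the aromatic nitrogen gives no change at the digits printed from compound 2 to compound 4 (within the scatter), and 4-carbamoylpiperidin-1-yl in place of dimethylamino gives no change at the digits printed from compound 1 to compound 4 (within the scatter), so none of these three single changes moves the number beyond the scatter. No supporting data bear on why the reading stays flat.

Still open, from the compounds shown here alone, is whether a carboxylic acid or an amine in place of methoxy, or a longer chain in place of butyl, would move the reading in this assay beyond the scatter.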